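Chain extension from compound 1 toward compound 4

The compounds below may be only part of what the source reports. "The series", "measured", "known", "first", "only" and "open" are said of these compounds alone.

Compound 1 `c1ccc2c(c1)CN[C@@H](CN(CCCN1CCNCC1)[C@H]1CCCc3cccnc31)C2` holds the highest of the three numbers in an ADME assay on microsomes from liver (Rattus norvegicus) for metabolic stability, read by LC-MS, with a stated time of 10 min, tested at 0.5 uM (on this read-out lower numbers stand for a less stable compound and higher numbers for a more stable compound), where compound 1 gives 100%. Compound 2 `c1cnc2c(c1)CN[C@H](CN(CCCN1CCNCC1)[C@H]1CCCc3cccnc31)C2` gives 87%, a step of a number 13 percentage points lower from compound 1 to compound 2 (beyond the scatter). Compound 3 `c1cnc2c(c1)CN[C@@H](CN(CCCN1CCNCC1)[C@H]1CCCc3cccnc31)C2` gives 79%, a step of a number 21 percentage points lower from compound 1 to compound 3 (beyond the scatter). Between these two the step is a number 8 percentage points lower from compound 2 to compound 3 (within the scatter), which is read against (the fact that compounds 2 and 3 differ only in the configuration as drawn).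

Compound 4 `c1ccc2c(c1)CN[C@@H](CN(CCCCN1CCNCC1)[C@H]1CCCc3cccnc31)C2` differs from compound 1 in the chain: (piperazin-1-yl)methyl in place of piperazin-1-yl on a saturated chain carbon, three bonds along the chain from an amine nitrogen. Within the data shown here, neither measured step concerns the chain; both touch the aromatic ring or the configuration, so no measured step bears directly on this change, and the two beyond-scatter steps of the set are only modest. A step in this assay is therefore expected to stay small, at most a modest move downward, as compound 1 already sits at the top of the scale.

For compound 4 the expected number in this assay is 92%, within 78% to 100%, which means an expected step of a number 8 percentage points lower from compound 1 to compound 4 (within the scatter).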

Compound 4, percent of the compound remaining: 15%
Compound 4: middle estimate off by 77 percentage points, on the high side, outside the stated range (below it).
By their numbers in this assay, from the lowest: compound 4; then compounds 3 and 2 (each within the scatter of the next); then compound 1.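

Within this assay, the saturated chain carbon three bonds along the chain from an amine nitrogen is a sensitive place: (piperazin-1-yl)methyl in place of piperazin-1-yl gives the step (a number 85 percentage points lower from compound 1 to compound 4 (beyond the scatter)). This single change in the chain moves the read-out much further than either change in the aromatic ring (a number 13 percentage points lower from compound 1 to compound 2 (beyond the scatter); a number 21 percentage points lower from compound 1 to compound 3 (beyond the scatter)), so the top value of compound 1 does not carry over to this chain. Nothing measured in this set accounts for the step.

Going by these compounds, whether a longer chain, such as 5-(piperazin-1-yl)pentyl, continues the fall remains open, as does the effect of a morpholine in place of the piperazine on either chain. Also open, on these data alone, is how the aromatic ring change of compounds 2 and 3 reads on the chain of compound 4.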